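This account rests on a few compounds, and the source may have more. Where it says the series, first, only, none or still open, it means among the compounds named here.

Compound 1, `COc1cccc2c1nc(-c1c(F)cccc1F)n2Cc1c(F)cccc1F`, gives 44.3 uM in a toxicity assay on CCRF-CEM cells (Homo sapiens) for cytotoxicity; on this read-out lower numbers stand for higher toxicity in this test and higher numbers for lower toxicity in this test. Compound 2, `Oc1cccc2c1nc(-c1c(F)cccc1F)n2Cc1c(F)cccc1F`, reaches only the limit of > 100 uM in this assay. Compound 3, `CC(=O)N(C)c1cccc2c1nc(-c1c(F)cccc1F)n2Cc1c(F)cccc1F`, also reaches only the limit of > 100 uM in this assay.

Among the measured compounds shown here, compound 1 is thus the only compound with a number in this assay; the other two sit at a limit. Compound 4, `CC(=O)N(C)Cc1cccc2c1nc(-c1c(F)cccc1F)n2Cc1c(F)cccc1F`, differs from compound 1 by (acetyl(methyl)amino)methyl in place of methoxy on an aromatic carbon. For the measured compounds named here, two measured steps bear on this change. There is an at least 2.2-fold higher number from compound 1 to compound 2 (0.35 log units; beyond the scatter), and there is an at least 2.2-fold higher number from compound 1 to compound 3 (0.35 log units; beyond the scatter). The step that the two limits leave unreadable from compound 2 to compound 3. Both changes made to compound 1 at this place lead to the limit of > 100 uM in this assay, at which 2 of the 3 values shown sit, and compound 4 shares its acetyl(methyl)amino part with compound 3. An at least modest rise in the number is therefore expected from compound 1 to compound 4, with a fair chance of a limit only; the expected step is a 2.3-fold higher number from compound 1 to compound 4 (0.35 log units; beyond the scatter). Compound 4 is estimated at 100 uM in this assay, within a range of 40 uM to 250 uM.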

Compound 4, half-maximal toxic concentration: 20.6 uM
The estimate for compound 4 lay 4.9-fold (0.69 log units) above the measured number; the measured number lies below the stated range.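

At this aromatic carbon, the (acetyl(methyl)amino)methyl group moves the read-out in this assay the opposite way from the two earlier changes, with a 2.2-fold lower number from compound 1 to compound 4 (0.33 log units; beyond the scatter). Compound 3 and compound 4 share the acetyl(methyl)amino part, yet there is an at least 4.8-fold lower number from compound 3 to compound 4 (0.68 log units; beyond the scatter), so that shared part does not by itself carry the higher number over. There is also an at least 4.8-fold lower number from compound 2 to compound 4 (0.68 log units; beyond the scatter), which sets compound 4 apart from the compounds held at a limit: the limit of > 100 uM in this assay, at which 2 of the 4 values shown sit.

The compounds shown leave open whether a longer chain carrying the acetyl(methyl)amino part, or an amine or a carboxylic acid at this aromatic carbon, would fall with compound 4 or with compound 3. They also leave open how compound 2 and compound 3 compare with each other, since neither has a number.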